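The source may report more compounds than this note shows. Statements on the series, on what has been measured and on what is new or still open speak of the compounds shown alone.

Measured in a functional assay on HepG2 cells (Homo sapiens) for antiproliferative activity, read by MTT assay, with a stated time of 48 h; on this read-out higher numbers stand for weaker inhibition and lower numbers for stronger inhibition:
- compound 1 `COc1ccc(N(C)c2ccnc(Cl)n2)cc1[N+](=O)[O-]`: 6120 nM
- compound 2 `COc1ccc(N(C)c2ccnc(Cl)n2)cc1O`: 464 nM
- compound 3 `COc1ccc(N(C)c2ccnc(Cl)n2)cc1OCCCBr`: 1240 nM

Compound 3 holds the middle place of the three numbers, above compound 2 and below compound 1. The next analogue, compound 4 `COc1ccc(N(C)c2ccnc(Cl)n2)cc1OCC[Se]C#N`, has not yet been measured in this assay. It differs from compound 3 as follows: a group of 3 heavy atoms (1 carbon, 1 nitrogen, 1 selenium; no ring) in place of a group of 2 heavy atoms (1 carbon, 1 bromine; no ring), on a saturated chain carbon, two bonds along the chain from an oxygen on an aromatic ring. The change lies on a saturated chain carbon, two bonds along the chain from an oxygen on an aromatic ring.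

Three measured steps frame it. The closest is a 2.7-fold higher number from compound 2 to compound 3 (0.43 log units; beyond the scatter), which adds the 3-bromopropyl group. The others are a 4.9-fold lower number from compound 1 to compound 3 (0.69 log units; beyond the scatter) and a 13-fold lower number from compound 1 to compound 2 (1.12 log units; beyond the scatter). None of them tests the entering group, so they give only a rough guide to size. A modest step is expected, leaning towards a lower number, with compound 2 at 464 nM as the nearest reference. The expected step is a 2.3-fold lower number from compound 3 to compound 4 (0.35 log units; beyond the scatter). For compound 4 the estimated value is 550 nM, with an expected range of 130 nM to 2000 nM.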

Compound 4, half-maximal inhibitory concentration: 1670 nM
Compound 4: the middle estimate sits 3.0-fold (0.48 log units) below what was measured; low and high end bracket the measured number.
By their numbers in this assay, from the lowest: compound 2; then compounds 3 and 4 (each within the scatter of the next); then compound 1.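

In this assay, the exchange at this saturated chain carbon gives a 1.3-fold higher number from compound 3 to compound 4 (0.13 log units; within the scatter), so the bromomethyl end and the entering selenium-and-nitrile group cannot be told apart on this read-out. Placing the longer selenium-bearing group on the oxygen of the free hydroxy gives a 3.6-fold higher number from compound 2 to compound 4 (0.56 log units; beyond the scatter), while replacing the nitro group with the whole side chain gives a 3.7-fold lower number from compound 1 to compound 4 (0.56 log units; beyond the scatter), which leaves compound 2 with the lowest number of the four. Nothing shown explains why these numbers fall as they do.

It remains open whether selenium itself contributes anything, since no sulfur counterpart or plain nitrile on the chain is among these compounds. Equally open, going by these compounds, is how an amine, a carboxylic acid or a longer chain at this position would compare with compound 3.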